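Chalcone Analogues: From a Methoxypyridine to a Chlorohydroxyphenyl

This account rests on a few compounds, and the source may have more. Where it says the series, first, only, none or still open, it means among the compounds named here.

Compound 1, `COc1ccc(C(=O)/C=C/c2ccc3ccccc3n2)c2c1C=CC(C)(C)O2`: 4530 nM
Compound 2, `COc1ccc(/C=C/C(=O)c2ccc(OC)c3c2OC(C)(C)C=C3)cn1`: > 10000 nM
Compound 3, `CCOc1cc(/C=C/C(=O)c2ccc(OC)c3c2OC(C)(C)C=C3)ccc1O`: > 10000 nM

Three chalcones built on the same core have been tested in a functional assay on HCT-116 cells (Homo sapiens) for antiproliferative activity, read by MTT assay, with a stated time of 24 h; on this read-out higher numbers stand for weaker inhibition and lower numbers for stronger inhibition. Compound 1 gives 4530 nM. For compound 2 the assay reports only a limit, > 10000 nM. For compound 3 the result is likewise a limit, > 10000 nM. Thus there is the limit of > 10000 nM in this assay, at which 2 of the 3 values shown sit, and compound 2 sits at that limit, so no number is known for it; only compound 1 has a value inside the range of this assay.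

The next compound, compound 4, `COc1ccc(C(=O)/C=C/c2cc(Cl)ccc2O)c2c1C=CC(C)(C)O2`, differs from compound 2 in one place: 5-chloro-2-hydroxyphenyl in place of 6-methoxypyridin-3-yl on a double-bonded chain carbon bound to a double-bonded chain carbon. Among the compounds with values here, no pair of measured compounds differs in a single place, so no measured step in this assay tells how such a change acts on the shared core. Compound 1, whose chain end carries a different aromatic group, shows that a number inside the range is attainable, but it does not fix the size of the change from compound 2.

Compound 4 is therefore expected to move modestly toward stronger inhibition, with the step of an at least 1.6-fold lower number from compound 2 to compound 4 (0.22 log units; that floor lies within the scatter), and to give roughly 6000 nM, within 2000 nM to 20000 nM.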

Compound 4, half-maximal inhibitory concentration: 5240 nM
The estimate for compound 4 lay 1.1-fold (0.06 log units) above the measured number; low and high end bracket the measured number.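

Setting 5-chloro-2-hydroxyphenyl in place of 6-methoxypyridin-3-yl on a double-bonded chain carbon bound to a double-bonded chain carbon gives, in this assay, the first step that can be read on the shared core: an at least 1.9-fold lower number from compound 2 to compound 4 (0.28 log units; that floor lies within the scatter). The change thus separates two compounds of which only compound 4 has a number inside the range of the assay, so this place on the chain can carry a group that yields a measurable value, even though the printed floor alone does not establish a change larger than the usual scatter. The true size of the step stays unknown because compound 2 sits at a limit of the assay: the limit of > 10000 nM in this assay, at which 2 of the 4 values shown sit.

The compounds shown leave open how far the step extends beyond its floor and whether it comes from the chlorine, from the hydroxy group or from the two together, as the step exchanges the whole aromatic group at once. They also leave open what a plain phenyl, or a phenyl bearing an amine or a carboxylic acid in place of the hydroxy group, would give at this place.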